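Methyl on the Core of Compound 3: An Expected Maximal Response

A few compounds are considered here, and "the series" means these few. Any claim that something is new, unique, unknown or untested is made for them only; others in the source may bear on it.

Compound 3 `CC(C)c1noc(N2CCC(Oc3ncnc4c3CCN4c3ccc(S(C)(=O)=O)cc3F)CC2)n1` stands second highest of three measured compounds in a functional assay on CHO-K1 cells with Glucose-dependent insulinotropic receptor (Homo sapiens) as the target, read by a luciferase reporter, with a stated time of 5 h (on this read-out higher numbers stand for larger maximal responses and lower numbers for smaller maximal responses), where compound 3 gives 124%. Its nearest neighbour is compound 1 `CCCCOC(=O)N1CCC(Oc2ncnc3c2CCN3c2ccc(S(C)(=O)=O)cc2F)CC1`, which gives 131%; the step is a number 7 percentage points lower from compound 1 to compound 3 (within the scatter), within the scatter. The furthest is compound 2 `CS(=O)(=O)c1ccc(N2CCc3c(OC4CCN(C(=S)Sc5ccccc5)CC4)ncnc32)c(F)c1`, which gives 103%; the step is a number 21 percentage points higher from compound 2 to compound 3 (beyond the scatter), beyond the scatter. Between the other two the step is a number 28 percentage points lower from compound 1 to compound 2 (beyond the scatter).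

Compound 4 `Cc1nc(OC2CCN(c3nc(C(C)C)no3)CC2)c2c(n1)N(c1ccc(S(C)(=O)=O)cc1F)CC2` differs from compound 3 by methyl in place of hydrogen on an aromatic carbon, on an aromatic carbon of a six-membered aromatic ring with 2 nitrogen, part of a fused or bridged system of two rings, between two ring nitrogen atoms. Going by these compounds, all three measured steps change the group on an amine nitrogen in a ring, so none bears on this change; the effect of a methyl on the core of compound 3 is untested. Among the compounds with values here, with no bearing step, no change beyond the scatter is expected, and the step to compound 4 is estimated as a number 2 percentage points lower from compound 3 to compound 4 (within the scatter). In this assay compound 4 is therefore expected to give 122%, in the range 102% to 142%.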

Compound 4, largest response reached (reported as percent of maximum), in percent of the reference or control that the assay uses: 44%
Compound 4: the middle estimate sits 78 percentage points above what was measured; the measured number lies below the stated range.
By their numbers in this assay, from the lowest: compound 4; then compound 2; then compounds 3 and 1 (each within the scatter of the next).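

In this assay, this aromatic carbon between two ring nitrogen atoms proves highly sensitive to substitution: methyl in place of hydrogen gives a number 80 percentage points lower from compound 3 to compound 4 (beyond the scatter) and is the largest step in the series. The steps among compound 1, compound 2 and compound 3 changed only the group on the amine nitrogen in a ring, so they gave no sign that the core could be this sensitive to a single added carbon. No measurement here accounts for the fall in maximal response.

Going by these compounds, it remains open whether an ethyl group, a methoxy group, an amine or a chlorine atom on this aromatic carbon would behave as methyl does. On these data alone, it is also open whether methyl would have the same effect with the butoxycarbonyl group of compound 1 on the amine nitrogen.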